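Hydroxy to methoxy on the core of compound 1

The source may report more compounds than this note shows. Statements on the series, on what has been measured and on what is new or still open speak of the compounds shown alone.

Measured in a functional assay on HL-60 cells (Homo sapiens) for cytotoxicity; on this read-out higher numbers stand for lower toxicity in this test and lower numbers for higher toxicity in this test:
compound 1 `COc1cc(/C=C2\Cc3ccccc3/C(=C\c3ccc([N+](=O)[O-])cc3)C2=O)ccc1O`: 950 nM
compound 2 `COc1cc(/C=C2\CCC/C(=C\c3ccc([N+](=O)[O-])cc3)C2=O)ccc1O`: 3400 nM
compound 3 `COc1ccc(/C=C2\CCC/C(=C\c3ccc([N+](=O)[O-])cc3)C2=O)cc1OC`: 4300 nM

Compound 1 has the lowest number of the three in this assay; its gaps to compound 2 and to compound 3 both lie beyond the scatter, so among these three it is the most cytotoxic in this test. Compound 2 and compound 3 share a different core and lie within the scatter of each other.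

Compound 4 `COc1ccc(/C=C2\Cc3ccccc3/C(=C\c3ccc([N+](=O)[O-])cc3)C2=O)cc1OC` differs from compound 1 by methyl in place of hydrogen on an oxygen on an aromatic ring. For the measured compounds named here, the only measured step of the same kind is the one on the core of compound 2, which reads a 1.3-fold higher number from compound 2 to compound 3 (0.10 log units; within the scatter) and so changed nothing beyond the scatter. No other measured pair bears on this change, and whether the core of compound 1 behaves the same way is not shown by the data. Taking the one measured step as the guide, the step from compound 1 to compound 4 is expected to be a 1.2-fold higher number from compound 1 to compound 4 (0.06 log units; within the scatter), with no change beyond the scatter. Compound 4 is therefore estimated at 1100 nM in this assay, within a range from 500 nM to 2600 nM.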

Compound 4, half-maximal cytotoxic concentration: 560 nM
Compound 4: the middle estimate sits 2.0-fold (0.29 log units) above what was measured, and the stated range covers the measured number.
By their numbers in this assay, from the lowest: compounds 4 and 1 (each within the scatter of the next); then compounds 2 and 3 (each within the scatter of the next).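

In this assay, hydroxy to methoxy on the core of compound 1 gives a 1.7-fold lower number from compound 1 to compound 4 (0.23 log units; within the scatter), so the change now stays within the scatter on a second core. The earlier compounds shown here showed this on one core only, and the two steps do not separate from each other: the same change on two cores in this assay, a 1.3-fold higher number (0.10 log units; within the scatter) from compound 2 to compound 3 and a 1.7-fold lower number (0.23 log units; within the scatter) from compound 1 to compound 4, 2.1-fold (0.33 log units) apart, within the scatter of two such steps. With the methoxy on both cores, compound 4 reads 560 nM and compound 3 reads 4300 nM, so the two cores stay apart in their printed values, as they do with the hydroxy.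

On these data alone, whether a longer chain on this oxygen, such as ethyl or benzyl, would also stay within the scatter remains open on both cores, as does an amine in place of the hydroxy. The nitro group stays fixed throughout the compounds shown, so a carboxylic acid in its place is open too.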